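Swapping the aryl group on the alkyne of compound 2

This account rests on a few compounds, and the source may have more. Where it says the series, first, only, none or still open, it means among the compounds named here.

compound 1 `Cc1cccc(C#Cc2ccc3c(n2)CCN(C2CCCC2)C3=O)c1`: 670 nM
compound 2 `O=C1c2ccc(C#Cc3ccccc3Cl)nc2CCN1C1CCCC1`: > 32000 nM

In an assay on HEK293 cells for displacement of a labelled ligand from metabotropic glutamate receptor 5 (Homo sapiens), with a stated time of 2 h (on this read-out lower numbers stand for stronger inhibition and higher numbers for weaker inhibition), compound 1 gives 670 nM. Going by these compounds, compound 2 is reported only as a limit of the assay, > 32000 nM, so its true value is unknown. Within the data shown here, the single measured step, an at least 47-fold higher number from compound 1 to compound 2 (1.67 log units; beyond the scatter), ends at the limit of > 32000 nM in this assay, at which 1 of the 2 values shown sits. Compound 3 `COc1cccc(C#Cc2ccc3c(n2)CCN(C2CCCC2)C3=O)c1` is not yet measured; it differs from compound 2 by 3-methoxyphenyl in place of 2-chlorophenyl on a triple-bonded carbon. Among the measured compounds shown here, that change restores a group placed like the one in compound 1, so a large drop in the number is expected, with an at least 32-fold lower number from compound 2 to compound 3 (1.50 log units; beyond the scatter) as the estimated step. Compound 3 is therefore estimated at 1000 nM, within 250 nM to 5000 nM.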

Compound 3, inhibition constant: > 32000 nM
Compound 3: a limit, no number; the forecaster's own chance of this, stated with the estimate: 5%; at least 32-fold (1.50 log units) between middle value and limit.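

Methoxy in place of methyl on an aromatic carbon gives an at least 47-fold higher number from compound 1 to compound 3 (1.67 log units; beyond the scatter) in this assay, so on this shared core the methyl of compound 1 cannot be exchanged for methoxy without losing a measurable number. The step from compound 2 to compound 3 cannot be read, and compound 1 remains the only compound here with a true number: the limit of > 32000 nM in this assay, at which 2 of the 3 values shown sit.

Going by these compounds, whether a different group at that place, such as ethyl, fluorine or an amine, would keep a measurable number stays open. On these data alone, whether compound 2 and compound 3 truly differ also stays open.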